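The source may hold more compounds than are shown below. What is called first, only, known or untested is meant among the compounds shown, and "the series" means these compounds.

Measured compounds in a functional assay on CHO cells with adenosine receptor A1 (Homo sapiens) as the target, read by cAMP accumulation and immunoassay, with a stated time of 6 min, tested at 0.01 uM; on this read-out lower numbers stand for a stronger effect and higher numbers for a weaker effect at the one concentration tested:
- compound 1, `Nc1scc(CN2CCN(c3cc(Cl)cc(Cl)c3)CC2)c1C(=O)c1ccc(Cl)cc1`: -1%
- compound 2, `Nc1scc(CN2CCN(c3ccncc3)CC2)c1C(=O)c1ccc(Cl)cc1`: -4%
- compound 3, `Nc1scc(CN2CCN(c3c(F)cc(F)cc3F)CC2)c1C(=O)c1ccc(Cl)cc1`: 4.2%

All three values sit close together. Compound 3, with 4.2% in this assay, is separated from compound 1 by a number 5.2 percentage points higher from compound 1 to compound 3 (within the scatter) and from compound 2 by a number 8.2 percentage points higher from compound 2 to compound 3 (within the scatter); neither step exceeds the scatter, so compound 3 cannot be set apart from the other two on these numbers.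

Compound 4, `Nc1scc(CN2CCN(c3ccc(F)c(Cl)c3)CC2)c1C(=O)c1ccc(Cl)cc1`, differs from compound 3 in one place: 3-chloro-4-fluorophenyl in place of 2,4,6-trifluorophenyl on an amine nitrogen in a ring. Every measured step in this small set changes the same aryl group on the same ring nitrogen, and each of them, a number 3 percentage points lower from compound 1 to compound 2 (within the scatter) as well as a number 5.2 percentage points higher from compound 1 to compound 3 (within the scatter) and a number 8.2 percentage points higher from compound 2 to compound 3 (within the scatter), stays within the scatter. Those steps bear directly on the present change, and on their basis no movement beyond the scatter is expected for compound 4 in this assay, in either direction; the expected step is a number 3.2 percentage points lower from compound 3 to compound 4 (within the scatter). The estimate for compound 4 is 1%, with a range from -9% to 11%.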

Compound 4, a percentage reported as activity, at one concentration (the size of the read-out at that concentration, not a potency): 4.2%
The estimate for compound 4 lay 3.2 percentage points below the measured number, within the range that was stated.
By their numbers in this assay, from the lowest: compounds 2, 1, 3 and 4 (each within the scatter of the next).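

In this assay, replacing the aryl group on the ring nitrogen with 3-chloro-4-fluorophenyl gives no change at the digits printed from compound 3 to compound 4 (within the scatter) and also a number 8.2 percentage points higher from compound 2 to compound 4 (within the scatter) and a number 5.2 percentage points higher from compound 1 to compound 4 (within the scatter) in the comparisons with the other aryl groups. The read-out at this position therefore does not separate a phenyl carrying both chlorine and fluorine from the trifluorophenyl, dichlorophenyl or pyridin-4-yl groups, so this change adds a further aryl group to those that cannot be told apart. No data at hand explain this lack of separation. Still open, on these data alone, is whether a group other than an aromatic ring on this nitrogen, such as benzyl or cyclohexyl, or an aryl group bearing a carboxylic acid or an amine, would give a step beyond the scatter. A single concentration also leaves open whether these compounds would show a stronger or weaker effect relative to one another at any other concentration.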